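Vero cytotoxicity notes: chloro to methoxy on compound 2

The source may hold more compounds than are shown below. What is called first, only, known or untested is meant among the compounds shown, and "the series" means these compounds.

compound 1, `CC(=O)c1ccc(Nc2nc(NCCC(C)C)nc3[nH]cnc23)cc1`: 85000 nM
compound 2, `Cc1cc(OCc2cccc(F)c2)cc(=O)n1Cc1ccc(Cl)cc1`: < 6400 nM

Two compounds have been run in an ADME assay on Vero cells (Chlorocebus sabaeus) for cytotoxicity; a higher number here means that more compound is tolerated, a lower number that less compound is tolerated. Compound 1 gives 85000 nM. For compound 2 the read-out is a limit of the assay, < 6400 nM, so its half-maximal cytotoxic concentration is known only as a bound (the limit of < 6400 nM in this assay, at which 1 of the 2 values shown sits). Among the measured compounds shown here, no pair of measured compounds differs in a single place, so no measured step is available. Compound 3, `COc1ccc(Cn2c(C)cc(OCc3cccc(F)c3)cc2=O)cc1`, is next to be measured. It differs from compound 2 in one place: methoxy in place of chloro on an aromatic carbon, on an aromatic carbon of a six-membered aromatic ring of carbon only, para to a large group. With compound 2 known only as a limit, the step has no firm anchor. The change is small and the expected step from compound 2 to compound 3 is a step that the limit leaves unreadable from compound 2 to compound 3, within the scatter or a slight rise in tolerated concentration. Compound 3 is therefore expected to give about 6000 nM, with a range from 1500 nM to 20000 nM, and a limit-only result remains a fair chance.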

Compound 3, half-maximal cytotoxic concentration: < 6400 nM
Compound 3 ended at the assay's limit; the forecaster's own chance of this, stated with the estimate: 45%; the middle value lies beyond the limit too.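

In this assay compound 2 and compound 3 both end at the assay's limit, so no step can be read for 4-chlorophenyl to 4-methoxyphenyl: the limit of < 6400 nM in this assay, at which 2 of the 3 values shown sit.

Still open, as far as these compounds go, is how far the true half-maximal cytotoxic concentration of each compound lies from that limit, and whether the swap changes it at all.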